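This account rests on a few compounds, and the source may have more. Where it says the series, first, only, none or still open, it means among the compounds named here.

Compound 1 `Nc1nc2cc(Cl)c(Cl)cc2n1Cc1ccccc1`: 170000 nM
Compound 2 `Clc1cc2nc(Br)n(Cc3ccccc3)c2cc1Cl`: > 100000 nM
Compound 3 `CC(C)Nc1nc2cc(Cl)c(Cl)cc2n1Cc1ccccc1`: 45000 nM

These results come from a functional assay on KB cells (Homo sapiens) for inhibition; on this read-out higher numbers stand for weaker inhibition and lower numbers for stronger inhibition. The entry for compound 2 is a limit, not a number. Of the two real numbers, compound 3 holds the lower, and compound 1 is its nearest neighbour. Compound 4 `Clc1cc2nc(NC3CC3)n(Cc3ccccc3)c2cc1Cl` keeps the shared core of compound 3 and changes one group: cyclopropyl in place of isopropyl on a nitrogen on an aromatic ring. The closest measured evidence is a 3.8-fold lower number from compound 1 to compound 3 (0.58 log units; beyond the scatter), where isopropyl replaced hydrogen on that same nitrogen. Against the limit, the data show an at least 2.2-fold lower number from compound 2 to compound 3 (0.34 log units; beyond the scatter). Neither step swaps one such group for another, so only a small change is expected, none beyond the scatter. The expected step is a 1.1-fold higher number from compound 3 to compound 4 (0.05 log units; within the scatter). For compound 4 the estimated value is 50000 nM, with an expected range of 20000 nM to 130000 nM.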

Compound 4, half-maximal inhibitory concentration: 60000 nM
Beside the measured number, compound 4's estimate is 1.2-fold (0.08 log units) below it; measured number inside the range.
By their numbers in this assay, from the lowest: compounds 3 and 4 (each within the scatter of the next); then compound 1.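

Closing the isopropyl into a cyclopropyl ring on this nitrogen leaves the read-out in this assay essentially unchanged, with a 1.3-fold higher number from compound 3 to compound 4 (0.12 log units; within the scatter). The drop seen on substituting the plain amino group therefore also appears with a second small carbon group, with a 2.8-fold lower number from compound 1 to compound 4 (0.45 log units; beyond the scatter), so it is not tied to isopropyl alone. Compound 2 holds a limit, not a number, and its step, an at least 1.6-fold lower number from compound 2 to compound 4 (0.22 log units; that floor lies within the scatter), settles little: the limit of > 100000 nM in this assay, at which 1 of the 4 values shown sits.

Going by these compounds, whether a longer chain, such as butyl, or a chain ending in an amine on this nitrogen would lower the number further stays open.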